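Compound 4: a ring swap near the limit

The source may hold more compounds than are shown below. What is called first, only, known or untested is meant among the compounds shown, and "the series" means these compounds.

In an ADME assay on HEK293 cells (Homo sapiens) for cytotoxicity, with a stated time of 72 h (on this read-out lower numbers stand for an effect already at smaller amounts and higher numbers for an effect only at larger amounts of compound), compound 3 (`Cc1cc(NC(=O)Nc2ncccc2C)c2ccccc2n1`) gives > 25000 nM, which is a limit and not a number. Compound 1 (`Cc1cc(NC(=O)Nc2cccc(C(N)=O)c2)c2ccccc2n1`) gives > 25000 nM, also a limit. Compound 2 (`COC(=O)c1cccc(NC(=O)Nc2cc(C)nc3ccccc23)c1`) gives an actual number, 26000 nM. Compound 3 therefore has no exact place among these compounds, and little about their order can be read because of the limit of > 25000 nM in this assay, at which 2 of the 3 values shown sit.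

The next compound, compound 4 (`Cc1cc(NC(=O)Nc2cccc(Cl)c2)c2ccccc2n1`), carries 3-chlorophenyl in place of 3-methylpyridin-2-yl on an amide-type nitrogen. Among the measured compounds shown here, only one measured step bears on this, a step that the limit leaves unreadable from compound 1 to compound 2, and it offers no size to carry over. That step also changes a different place, a group on a carbonyl carbon. For the measured compounds named here, the one available number, compound 2 at 26000 nM, is a high one. No step beyond the usual scatter is therefore expected in this assay, and neither direction is favoured. The estimated change is an at least 1.1-fold lower number from compound 3 to compound 4 (0.05 log units; that floor lies within the scatter). For compound 4 the expected value is 22000 nM, with an estimated range of 8000 nM to 50000 nM.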

Compound 4, half-maximal effective concentration: 21000 nM
Compound 4: middle estimate off by 1.0-fold (0.02 log units), on the high side, and the stated range covers the measured number.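

Putting 3-chlorophenyl in place of 3-methylpyridin-2-yl on an amide-type nitrogen gives, in this assay, an at least 1.1-fold lower number from compound 3 to compound 4 (0.07 log units; that floor lies within the scatter), so this swap now ends in a real number on one side, though the step itself is only a floor. Among the compounds shown here, compound 4 also allows the first step in this set with a readable size: chloro in place of methoxycarbonyl on an aromatic carbon gives a 1.2-fold lower number from compound 2 to compound 4 (0.09 log units; within the scatter), and chloro in place of carbamoyl on an aromatic carbon gives an at least 1.1-fold lower number from compound 1 to compound 4 (0.07 log units; that floor lies within the scatter). None of these steps is printed as going beyond the scatter, and two of them remain floors rather than sizes because values sit at a limit: the limit of > 25000 nM in this assay, at which 2 of the 4 values shown sit.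

As far as these compounds go, whether an amine or a carboxylic acid in place of chloro on the aromatic carbon would give a step beyond the scatter stays open. Also open, from the compounds shown here alone, is whether a longer chain in place of the 3-chlorophenyl on the amide-type nitrogen would bring a clear change in this read-out.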